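The source may hold more compounds than are shown below. What is called first, only, known or untested is meant among the compounds shown, and "the series" means these compounds.

- compound 1 `COc1cc2ncnc(Nc3ccc(NC(=O)c4ccccc4F)cc3)c2cc1OC`: 13000 nM
- compound 2 `COc1cc2ncnc(Nc3ccc(NC(=O)c4ccc(F)cc4)cc3)c2cc1OC`: 15000 nM
- compound 3 `COc1cc2ncnc(Nc3ccc(NC(=O)c4ccc(Br)cc4)cc3)c2cc1OC`: 35000 nM

In a functional assay on HepG2 cells (Homo sapiens) for inhibition, read by MTT assay (a higher number here means a weaker inhibitor, a lower number a stronger inhibitor), compound 3 has the highest number of the three, 35000 nM, which makes it the weakest inhibitor so far. Compound 4 `COc1cc2ncnc(Nc3ccc(NC(=O)c4cccc(C(F)(F)F)c4)cc3)c2cc1OC` has not yet been measured. It differs from compound 3 in one place: 3-(trifluoromethyl)phenyl in place of 4-bromophenyl on a carbonyl carbon. In other words, 3-(trifluoromethyl)phenyl stands in place of 4-bromophenyl on a carbonyl carbon.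

Within the data shown here, no measured compound carries trifluoromethyl, so the evidence is indirect. Changing the group on this carbonyl has so far made little difference. The two fluorinated compounds show a 1.2-fold higher number from compound 1 to compound 2 (0.06 log units; within the scatter). Bromo in place of fluoro gives a 2.3-fold higher number from compound 2 to compound 3 (0.37 log units; beyond the scatter), and the other step to the bromo compound is a 2.7-fold higher number from compound 1 to compound 3 (0.43 log units; beyond the scatter). Both of these are modest. Compound 4 has no bromo, like compound 1 at 13000 nM and compound 2 at 15000 nM, so only a small step towards a lower number is expected. The expected change is a 1.8-fold lower number from compound 3 to compound 4 (0.24 log units; within the scatter). For compound 4 the estimated value is 20000 nM, with an expected range of 8000 nM to 50000 nM.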

Compound 4, half-maximal inhibitory concentration: 83000 nM
The estimate for compound 4 lay 4.2-fold (0.62 log units) below the measured number; the whole stated range lies below it.
By their numbers in this assay, from the lowest: compounds 1 and 2 (each within the scatter of the next); then compound 3; then compound 4.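

In this assay the group on this carbonyl carbon matters more than the first three compounds showed: the step here (a 2.4-fold higher number from compound 3 to compound 4 (0.38 log units; beyond the scatter)) is beyond the scatter, and removing bromo did not bring the number back towards those of the fluoro compounds. Instead, the number moved further from them, and the two steps from those compounds (a 5.5-fold higher number from compound 2 to compound 4 (0.74 log units; beyond the scatter)) and (a 6.4-fold higher number from compound 1 to compound 4 (0.81 log units; beyond the scatter)) are the largest in this set, so the absence of bromo alone does not keep the number low. Nothing measured here explains why 3-(trifluoromethyl)phenyl gives this result.

Among these compounds, with only one trifluoromethyl compound, the effect of the group cannot be separated from that of its place on the ring. From the compounds shown here alone, it also remains open how this position responds to an amine or a carboxylic acid on the phenyl ring.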